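Working notes: from compound 2 to compound 3

The compounds below may be only part of what the source reports. "The series", "measured", "known", "first", "only" and "open" are said of these compounds alone.

Measured in a functional assay on A549 cells (Homo sapiens) for cytotoxicity, read by MTT assay, with a stated time of 72 h; a lower number here means a stronger inhibitor, a higher number a weaker inhibitor
- compound 1 `N#Cc1ccc(/C=N/NC(=O)Nc2cc3c(Nc4ccc(F)c(Cl)c4)ncnc3cc2O[C@H]2CCOC2)cc1` gives 29100 nM
- compound 2 `COc1cc(/C=N/NC(=O)Nc2cc3c(Nc4ccc(F)c(Cl)c4)ncnc3cc2O[C@H]2CCOC2)cc(OC)c1OC` gives 26400 nM

Compound 2 lies within the scatter of compound 1, so these two values set no order. Compound 3 `O=C(N/N=C/c1ccc(O)c(Br)c1)Nc1cc2c(Nc3ccc(F)c(Cl)c3)ncnc2cc1O[C@H]1CCOC1` has 3-bromo-4-hydroxyphenyl in place of 3,4,5-trimethoxyphenyl on a carbon with a double bond to nitrogen. Going by the values given here, the one measured step at this place is a 1.1-fold lower number from compound 1 to compound 2 (0.04 log units; within the scatter) and it stays within the scatter, though no measured compound carries the entering group. In this assay a step of a 1.2-fold lower number from compound 2 to compound 3 (0.08 log units; within the scatter) is therefore expected, with no change beyond the scatter. For compound 3 the estimate is 22000 nM with 9000 nM to 50000 nM as the expected range.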

Compound 3, half-maximal inhibitory concentration: 4310 nM
The estimate for compound 3 lay 5.1-fold (0.71 log units) above the measured number, outside the stated range (below it).
By their numbers in this assay, from the lowest: compound 3; then compounds 2 and 1 (each within the scatter of the next).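

In this assay the group on the carbon with a double bond to nitrogen now proves able to shift the number: 3-bromo-4-hydroxyphenyl gives a 6.1-fold lower number from compound 2 to compound 3 (0.79 log units; beyond the scatter) and a 6.8-fold lower number from compound 1 to compound 3 (0.83 log units; beyond the scatter) while the step between the two earlier groups stayed within the scatter. The same entering group thus holds against both 3,4,5-trimethoxyphenyl and 4-cyanophenyl. Nothing available accounts for this difference.

Going by these compounds, the bromine and the hydroxyl enter together, so their separate shares remain open. Also open, on these data alone, is whether an amine in place of the hydroxyl would keep the lower number.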